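Hydrogen in Place of (4-Chlorophenyl)carbonyl on the Ring Nitrogen

The source may hold more compounds than are shown below. What is called first, only, known or untested is meant among the compounds shown, and "the series" means these compounds.

Of the compounds shown here, three sharing one core have been tested in a functional assay on NUGC-3 cells (Homo sapiens) for inhibition, read by sulforhodamine B assay, with a stated time of 48 h; a higher number here means a weaker inhibitor of growth, a lower number a stronger inhibitor of growth. Compound 2 `COc1ccccc1NC(=O)C1c2ccccc2CCN1C(=O)c1ccc(Cl)cc1` gives 1590 nM and is the only one of the three with an actual number rather than a limit. Compound 1 `O=C(Nc1ccccc1O)C1c2ccccc2CCN1C(=O)c1ccc(Cl)cc1` reaches only the limit of > 10000 nM. Compound 3 `O=C(Nc1ccccc1C(F)(F)F)C1c2ccccc2CCN1C(=O)c1ccc(Cl)cc1` likewise reaches only the limit of > 10000 nM. Both of those values sit at the limit of > 10000 nM in this assay, at which 2 of the 3 values shown sit. The steps among these three all concern the substituent on the aromatic ring of the amide: an at least 6.2-fold lower number from compound 1 to compound 2 (0.79 log units; beyond the scatter), an at least 6.2-fold higher number from compound 2 to compound 3 (0.79 log units; beyond the scatter), and a step that the two limits leave unreadable from compound 1 to compound 3.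

Compound 4 `COc1ccccc1NC(=O)C1NCCc2ccccc21` differs from compound 2 at a different place: hydrogen in place of (4-chlorophenyl)carbonyl on an amine nitrogen in a ring. Among the measured compounds shown here, none of the measured steps touches this amine nitrogen in a ring, so no measured step bears directly on the change, and its size can only be guessed. With a large group leaving and only a hydrogen entering, compound 4 is expected to be a weaker inhibitor, and the step is expected to be a 5.0-fold higher number from compound 2 to compound 4 (0.70 log units; beyond the scatter). Compound 4 is accordingly estimated at 8000 nM, within a broad range from 2000 nM to 30000 nM, with a real chance that only a limit is reported.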

Compound 4, concentration for 50% growth inhibition: > 10000 nM
Compound 4 ended at the assay's limit (the forecaster's own chance of this, stated with the estimate: 45%); middle value at least 1.2-fold (0.09 log units) away from the limit.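

In this assay, putting hydrogen in place of (4-chlorophenyl)carbonyl on the amine nitrogen in a ring gives an at least 6.2-fold higher number from compound 2 to compound 4 (0.79 log units; beyond the scatter). Among the compounds shown here, this is the first evidence that the group on this nitrogen, and not only the substituent on the aromatic ring of the amide, affects growth inhibition: with the methoxy group of compound 2 kept, losing the (4-chlorophenyl)carbonyl is enough to lose the measurable value. The result for compound 4 is only a limit, so the true size of this loss cannot be read, and it joins the other compounds at the same ceiling: the limit of > 10000 nM in this assay, at which 3 of the 4 values shown sit.

As far as these compounds go, it remains open which part of the (4-chlorophenyl)carbonyl is needed. An acetyl group or a benzoyl group without the chlorine on this nitrogen would help separate the contribution of the carbonyl, the ring and the chlorine.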